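Changing the Amide Cap from Compound 2 to Compound 3

The source may hold more compounds than are shown below. What is called first, only, known or untested is meant among the compounds shown, and "the series" means these compounds.

Compound 1, `CCOC(=O)N1CCC(NS(=O)(=O)c2ccc(OC(=O)c3ccccc3)c3ccccc23)CC1`, gives 16.4 nM.
Compound 2, `COCC(=O)N1CCC(NS(=O)(=O)c2ccc(NC(=O)c3ccccc3C)c3ccccc23)CC1`, gives 15.8 nM.

Both numbers come from an assay on L1.2 cells for binding affinity to C-C chemokine receptor type 8 (Homo sapiens); on this read-out higher numbers stand for weaker inhibition and lower numbers for stronger inhibition. Compound 2 has the lower of the two numbers, but compound 1 sits so close to it that the two values fall within the usual scatter of repeated measurements, so nothing separates them. Both compounds share a core that ends in a ring-bound amide-type nitrogen carrying a carbonyl group, and they differ in what sits on that carbonyl carbon and in the group on the far side of the core.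

Compound 3, `Cc1ccccc1C(=O)Nc1ccc(S(=O)(=O)NC2CCN(C(=O)N3CCCC3)CC2)c2ccccc12`, has not yet been measured. It differs from compound 2 in one place: pyrrolidin-1-yl in place of methoxymethyl on a carbonyl carbon. The methoxymethyl group is replaced by pyrrolidin-1-yl on the carbonyl carbon whose other neighbour is the amide-type nitrogen in a ring.

For the measured compounds named here, no measured pair here isolates this change, so the expectation rests on the two values alone. Compound 3 is expected to show a step of a 1.1-fold lower number from compound 2 to compound 3 (0.02 log units; within the scatter), that is, nothing beyond the scatter in either direction. Compound 3 is therefore estimated at 15 nM, within a range from 5 nM to 45 nM.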

Compound 3, inhibition constant: 1.1 nM
Compound 3: middle estimate off by 14-fold (1.13 log units), on the high side, outside the stated range (below it).
By their numbers in this assay, from the lowest: compound 3; then compounds 2 and 1 (each within the scatter of the next).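

The group on this carbonyl carbon, whose other neighbour is the amide-type nitrogen in a ring, has a strong influence on binding: in this assay, pyrrolidin-1-yl in place of methoxymethyl gives a 14-fold lower number from compound 2 to compound 3 (1.16 log units; beyond the scatter), a large change from swapping one group. Compound 1 and compound 2 could not reveal this, as they differ in more than one place and their values lie within the scatter of each other, so their similar numbers said nothing about this position alone. No available measurement explains the gain.

The compounds shown leave open which feature of pyrrolidin-1-yl matters, as the swap adds a ring, replaces the oxygen of methoxymethyl with a nitrogen and enlarges the group all at once. A diethylamino group on the same carbonyl carbon would test whether the ring is needed, while a piperidin-1-yl group there would show whether a six-membered ring can match the five-membered one.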